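A few compounds are considered here, and "the series" means these few. Any claim that something is new, unique, unknown or untested is made for them only; others in the source may bear on it.

Compound 1, with the structure `COc1cc(-c2cc(/C=C/C(=O)c3ccc(N)cc3)[nH]n2)cc(OC)c1OC`, is the strongest of the three measured compounds in a functional assay on M14 cells (Homo sapiens) for cytotoxicity, read by sulforhodamine B assay, with a stated time of 48 h, tested at 10 uM (a higher number here means a weaker effect of the compound at the concentration tested, a lower number a stronger effect), where compound 1 gives -64%. Compound 2, with the structure `COc1ccc(-c2cc(/C=C/C(=O)c3ccc(OC)c(OC)c3)[nH]n2)cc1`, lies nearest to it; in this assay compound 2 gives -42%, a weaker effect that is beyond the scatter. Compound 3, with the structure `COc1cc(-c2cc(/C=C/C(=O)c3ccc(Cl)c(Cl)c3)[nH]n2)cc(OC)c1OC`, is furthest away, and in this assay compound 3 gives 61%. For the measured compounds named here, the one measured step between neighbours, a number 125 percentage points higher from compound 1 to compound 3 (beyond the scatter), is large and concerns the ring attached to the carbonyl.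

Compound 4, with the structure `COc1ccc(-c2cc(/C=C/C(=O)c3ccc(N)cc3)[nH]n2)cc1OC`, differs from compound 1 on the other ring: hydrogen in place of methoxy on an aromatic carbon. The change sits on an aromatic carbon of a six-membered aromatic ring of carbon only. Going by the values given here, no measured step covers this change; the step from compound 1 to compound 3 alters a different part of the molecule, and compound 2 differs from compound 1 in two places at once, so it gives only a loose hint that fewer methoxy groups on this ring go with a weaker effect. The step of a number 14 percentage points higher from compound 1 to compound 4 (beyond the scatter) is therefore expected to be modest and towards a weaker effect, if any. Compound 4 is estimated to give -50%, within a range from -85% to -5%.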

Compound 4, a percentage reported as activity, at one concentration (the size of the read-out at that concentration, not a potency): -42%
For compound 4 the middle estimate is 8 percentage points below the measured one; low and high end bracket the measured number.
By their numbers in this assay, from the lowest: compound 1; then compounds 2 and 4 (each within the scatter of the next); then compound 3.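

For the compounds shown here, the step of a number 22 percentage points higher from compound 1 to compound 4 (beyond the scatter) is the first direct reading on this ring: replacing one methoxy group, ortho to a methoxy group and meta to a large group, with hydrogen weakens the effect in this assay, so this methoxy group contributes to the effect of compound 1. The loss is only partial, since compound 4 still gives -42%, and this modest step is smaller than the large change on the ring attached to the carbonyl, a number 125 percentage points higher from compound 1 to compound 3 (beyond the scatter). Nothing available explains why removing this methoxy group weakens the effect.

What the compounds shown leave open is whether the methoxy group itself is needed at this place, or whether a hydroxy group, a fluorine atom or a longer chain such as ethoxy would keep the effect of compound 1. On these data alone, it also remains open whether replacing a methoxy group with hydrogen would weaken the effect to the same extent in a compound carrying the 3,4-dichlorophenyl group of compound 3.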